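Benzyl fluorine pattern on the shared core: next step

The source may report more compounds than this note shows. Statements on the series, on what has been measured and on what is new or still open speak of the compounds shown alone.

Measured so far, in an assay on Sf21 cells for inhibition of high affinity nerve growth factor receptor (Homo sapiens), read by HTRF, with a stated time of 30 min, in the presence of a further agent that is not named here; on this read-out lower numbers stand for stronger inhibition and higher numbers for weaker inhibition:
compound 1 `CC1(C)c2[nH]nc(NC(=O)c3ccccc3)c2CN1Cc1cccc(Br)c1` gives 940 nM
compound 2 `CC1(C)c2[nH]nc(NC(=O)c3ccccc3)c2CN1Cc1ccc(F)cc1` gives 1180 nM
compound 3 `CC1(C)c2[nH]nc(NC(=O)c3ccccc3)c2CN1Cc1cc(F)cc(F)c1` gives 190 nM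

Compound 3 holds the lowest number of the three: the steps of a 4.9-fold lower number from compound 1 to compound 3 (0.69 log units; beyond the scatter) and a 6.2-fold lower number from compound 2 to compound 3 (0.79 log units; beyond the scatter) both lie beyond the scatter, whereas a 1.3-fold higher number from compound 1 to compound 2 (0.10 log units; within the scatter) does not. Compound 4 `CC1(C)c2[nH]nc(NC(=O)c3ccccc3)c2CN1Cc1cccc(F)c1F` is not yet measured; the change from compound 3 is 2,3-difluorophenyl in place of 3,5-difluorophenyl on a saturated chain carbon bound to an amine nitrogen in a ring. Among the measured compounds shown here, no measured step tests this rearrangement directly. For the measured compounds named here, the two steps onto compound 3 show that the 3,5-difluorophenyl arrangement gave the lowest number so far, and compound 4 keeps only part of it. In this assay a modest upward step is therefore expected, a 2.1-fold higher number from compound 3 to compound 4 (0.32 log units; beyond the scatter), though it may stay within the scatter. Compound 4 is estimated at 400 nM, range 150 nM to 1200 nM.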

Compound 4, half-maximal inhibitory concentration: 200 nM
Compound 4: middle estimate off by 2.0-fold (0.30 log units), on the high side; the measured number falls inside the stated range.
By their numbers in this assay, from the lowest: compounds 3 and 4 (each within the scatter of the next); then compounds 1 and 2 (each within the scatter of the next).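

In this assay, 2,3-difluorophenyl in place of 3,5-difluorophenyl leaves the number within the scatter (a 1.1-fold higher number from compound 3 to compound 4 (0.02 log units; within the scatter)), so the low numbers at this position are not confined to the 3,5-difluorophenyl pattern. The new pattern also stands beyond the scatter of both monosubstituted phenyl groups (a 5.9-fold lower number from compound 2 to compound 4 (0.77 log units; beyond the scatter); a 4.7-fold lower number from compound 1 to compound 4 (0.67 log units; beyond the scatter)). Nothing available explains this result.

Still open, going by these compounds, is whether other difluorophenyl patterns behave alike. Also open, on these data alone, is whether a dichlorophenyl, methoxyphenyl or pyridyl group would hold this level.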